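Benzyl substituent variation: nitro analog expected at limit

The source may report more compounds than this note shows. Statements on the series, on what has been measured and on what is new or still open speak of the compounds shown alone.

Measured compounds, with their results in a functional assay on NIH3T3 cells (Mus musculus); a higher number here means that more compound is needed for the effect, a lower number that less compound is needed:
compound 1 `CSCC[C@H](NC(=O)c1ccc(NCc2cncn2Cc2ccc(C)cc2)cc1-c1ccccc1)C(=O)O`: > 10 uM
compound 2 `CSCC[C@H](NC(=O)c1ccc(NCc2cncn2Cc2ccc(C#N)cc2)cc1-c1ccccc1)C(=O)O`: > 10 uM
compound 3 `CSCC[C@H](NC(=O)c1ccc(NCc2cncn2Cc2ccccc2Cl)cc1-c1ccccc1)C(=O)O`: > 10 uM

Each of these values is a limit of this assay, not a number. Compound 3 stands at the limit of > 10 uM in this assay, at which 3 of the 3 values shown sit, as do the other two compounds. The steps a step that the two limits leave unreadable from compound 1 to compound 2, a step that the two limits leave unreadable from compound 1 to compound 3 and a step that the two limits leave unreadable from compound 2 to compound 3 therefore carry no readable size. Compound 4 `CSCC[C@H](NC(=O)c1ccc(NCc2cncn2Cc2ccc([N+](=O)[O-])cc2)cc1-c1ccccc1)C(=O)O` differs from compound 3 by 4-nitrophenyl in place of 2-chlorophenyl on a saturated chain carbon bound to an aromatic nitrogen. Whether a change of the benzyl substituent moves this read-out cannot be seen from the three compounds; all three values are limits. With no readable step to build on, compound 4 is expected to stay at the limit as well, and the step that the limit leaves unreadable from compound 3 to compound 4 is an estimate of wide uncertainty. The expected value for compound 4 is 25 uM, with a range from 5 uM to 150 uM.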

Compound 4, concentration for half-maximal effect: > 10 uM
Compound 4: a limit, no number (the forecaster's own chance of this, stated with the estimate: 85%); the middle value lies beyond the limit too.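

In this assay compound 4 gives > 10 uM, a limit and not a number, and its steps from compound 1, compound 2 and compound 3 cannot be read. Whether any change of the benzyl substituent moves this read-out remains open: the limit of > 10 uM in this assay, at which 4 of the 4 values shown sit.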